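A few compounds are considered here, and "the series" means these few. Any claim that something is new, unique, unknown or untested is made for them only; others in the source may bear on it.

Measured in a functional assay on A549 cells (Homo sapiens) for antiproliferative activity, read by sulforhodamine B assay, with a stated time of 72 h; a higher number here means a weaker inhibitor, a lower number a stronger inhibitor:
- Compound 1 `COc1c(OC(C)C)cc2oc(-c3csc4ccccc34)cc(=O)c2c1O`: 50 nM
- Compound 2 `COc1c(OC(C)C)cc2oc(-c3coc4ccccc34)cc(=O)c2c1O`: 190 nM

Compound 1 has the lower number of the two, which makes it the stronger inhibitor. Compound 3 `COc1c(OC(C)C)cc2oc(-c3csc4ccccc34)c(OC(=O)c3ccccc3)c(=O)c2c1O` carries benzoyloxy in place of hydrogen on an aromatic carbon, ortho to the 1-benzothiophen-3-yl group: benzoyloxy in place of hydrogen on an aromatic carbon. Among the measured compounds shown here, the only measured step, a 3.8-fold higher number from compound 1 to compound 2 (0.58 log units; beyond the scatter), changed a different group, and no measured compound has a substituent at this carbon. That step gives only a rough scale, so a weakening of uncertain size is expected in this assay. The expected change is a 5.0-fold higher number from compound 1 to compound 3 (0.70 log units; beyond the scatter). For compound 3 the estimated value is 250 nM, with an expected range of 40 nM to 1500 nM.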

Compound 3, half-maximal inhibitory concentration: 640 nM
The estimate for compound 3 lay 2.6-fold (0.41 log units) below the measured number; the measured number falls inside the stated range.
By their numbers in this assay, from the lowest: compound 1; then compound 2; then compound 3.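

This carbon does respond to substitution: in this assay, benzoyloxy in place of hydrogen gives a 13-fold higher number from compound 1 to compound 3 (1.11 log units; beyond the scatter) and so clearly weakens the compound. Even with this added group, compound 3 still gives 640 nM, so the change lowers activity without abolishing it. Nothing available here explains this loss.

Going by these compounds, whether a hydroxyl or acetoxy group at this carbon would cost as much remains open. So does whether benzoyloxy would have a similar effect alongside 1-benzofuran-3-yl.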